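The source may hold more compounds than are shown below. What is called first, only, known or untested is meant among the compounds shown, and "the series" means these compounds.

Measured in a functional assay on T47D cells (Homo sapiens) for inhibition, read by CCK-8 assay, with a stated time of 72 h, tested at 10 uM; on this read-out lower numbers stand for less inhibition of growth and higher numbers for more inhibition of growth at the one concentration tested:
- compound 1 `Cc1cccc(NC(=O)C2(C(=O)Nc3ccc(Nc4ncc5cc(C(=O)N(C)C)n(C6CCCC6)c5n4)cc3)CC2)c1`: 95.3%
- compound 2 `CN(C)C(=O)c1cc2cnc(Nc3ccc(NC(=O)C4(C(=O)Nc5ccccc5F)CC4)cc3)nc2n1C1CCCC1`: 97.8%
- compound 3 `Nc1ccc(NC(=O)C2(C(=O)Nc3ccc(F)cc3)CC2)cc1F`: 30.4%

Compound 2, at 97.8%, lies within the scatter of compound 1 and beyond the scatter above compound 3. Compound 4 `CN(C)C(=O)c1cc2cnc(Nc3ccc(NC(=O)C4(C(=O)Nc5cccc(Br)c5)CC4)cc3)nc2n1C1CCCC1` carries 3-bromophenyl in place of 2-fluorophenyl on an amide-type nitrogen. For the measured compounds named here, one measured step bears on this change, a swap at the same amide-type nitrogen: a number 2.5 percentage points higher from compound 1 to compound 2 (within the scatter). That step stayed within the scatter, so no shift beyond the scatter is expected in this assay. The expected change, an estimate, is a number 3.8 percentage points lower from compound 2 to compound 4 (within the scatter). The estimated value for compound 4 is 94%, with an expected range from 82% to 101%.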

Compound 4, percent growth inhibition at one concentration: 94.6%
Compound 4: middle estimate off by 0.6 percentage points, on the low side, and the stated range covers the measured number.
By their numbers in this assay, from the lowest: compound 3; then compounds 4, 1 and 2 (each within the scatter of the next).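

In this assay the amide-type nitrogen now carries 3-bromophenyl as well, and the change reads as a number 3.2 percentage points lower from compound 2 to compound 4 (within the scatter) while bromo in place of methyl on an aromatic carbon reads as a number 0.7 percentage points lower from compound 1 to compound 4 (within the scatter) in the same comparison. At this single concentration, the read-out therefore does not separate 3-bromophenyl from 2-fluorophenyl, or bromo from methyl. No evidence at hand explains this.

The compounds shown leave open whether a phenyl bearing an amine or a carboxylic acid on this amide-type nitrogen would stay within the scatter of these compounds.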